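Amide to urea linker on the core of compound 1

The source may report more compounds than this note shows. Statements on the series, on what has been measured and on what is new or still open speak of the compounds shown alone.

Compound 1 `COc1cc(-c2nn(-c3cccc(NC(=O)c4ccc(Cl)c(C(F)(F)F)c4)c3)cc2-c2ccncc2)ccc1Cl` is measured in a functional assay on M14 cells (Homo sapiens) for inhibition, read by sulforhodamine B assay, with a stated time of 48 h; a lower number here means that less compound is tolerated, a higher number that more compound is tolerated. Compound 1 gives only a limit there, > 32500 nM, and is therefore not placed on a number. This is the one point sitting at the limit of > 32500 nM in this assay, at which 1 of the 2 values shown sits. Compound 2 `O=C(Nc1cccc(-n2cc(-c3ccncc3)c(-c3ccc(Cl)c(O)c3)n2)c1)Nc1cc(C(F)(F)F)cc(C(F)(F)F)c1`, a urea with a different aryl group and a hydroxy in place of the methoxy on the other ring, gives 6060 nM in this assay. Compound 3 `COc1cc(-c2nn(-c3cccc(NC(=O)Nc4ccc(Cl)c(C(F)(F)F)c4)c3)cc2-c2ccncc2)ccc1Cl` differs from compound 1 by (4-chloro-3-(trifluoromethyl)phenyl)amino in place of 4-chloro-3-(trifluoromethyl)phenyl on a carbonyl carbon, so that the carbonyl carbon now carries two nitrogens. Within the data shown here, no step between measured compounds is available for this change. Since compound 2, the only measured urea, sits at a number while compound 1 sits at a limit, the step from compound 1 to compound 3 is expected to be toward a lower value, roughly an at least 2.7-fold lower number from compound 1 to compound 3 (0.43 log units; beyond the scatter). For compound 3 an estimate of 12000 nM is made, with a range from 4000 nM to 32500 nM.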

Compound 3, concentration lethal to 50% of the cells: 19100 nM
Compound 3: the middle estimate sits 1.6-fold (0.20 log units) below what was measured; measured number inside the range.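

On the core of compound 1, the change from 4-chloro-3-(trifluoromethyl)phenyl to (4-chloro-3-(trifluoromethyl)phenyl)amino on the carbonyl carbon can now be read directly. In this assay it amounts to an at least 1.7-fold lower number from compound 1 to compound 3 (0.23 log units; that floor lies within the scatter). The full size of the step cannot be read because compound 1 is held at a limit of the assay rather than a number: the limit of > 32500 nM in this assay, at which 1 of the 3 values shown sits.

Compound 2 differs from compound 3 in more than one place, so the separate contributions of its aryl group and its hydroxy remain unresolved. Also open, as far as these compounds go, is how a sulfonamide or a longer chain carrying the same 4-chloro-3-(trifluoromethyl)phenyl group would read at this position on the shared core.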